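This account rests on a few compounds, and the source may have more. Where it says the series, first, only, none or still open, it means among the compounds named here.

Of the compounds shown here, three have so far been measured in a physicochemical assay for lipophilicity; a lower number here means a more polar compound, a higher number a more lipophilic compound. Compound 1 `CCC(=O)OC[C@H]1C[C@]2(OC(=O)/C=C/c3ccccc3)C(=O)/C(C)=C/[C@@H]3[C@H](CC[C@@]4(C)O[C@@H]4[C@H]2[C@H]1OC(=O)CC)C3(C)C` gives 6.9, and compound 2 `CCCC(=O)OC[C@H]1C[C@]2(OC(=O)/C=C/c3ccccc3)C(=O)/C(C)=C/[C@@H]3[C@H](CC[C@@]4(C)O[C@@H]4[C@H]2[C@H]1OC(=O)CCC)C3(C)C` gives 8. Compound 3 `C=C1[C@@H](OC(=O)C(C)CC)[C@@H](OC(C)=O)C(=O)C(C)(C)/C=C/[C@H](C)[C@H](OC(=O)c2ccccc2)[C@@]2(O)C[C@H](C)[C@H](OC(C)=O)[C@@H]2[C@H]1OC(C)=O` gives 4.5, the lowest of the three numbers, and its gaps up to compound 1 and up to compound 2 both lie beyond the usual scatter of repeated measurements.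

Compound 4 `C=C1[C@@H](OC(=O)C(C)C)[C@@H](OC(C)=O)C(=O)C(C)(C)/C=C/[C@H](C)[C@H](OC(=O)c2ccccc2)[C@@]2(O)C[C@H](C)[C@H](OC(C)=O)[C@@H]2[C@H]1OC(C)=O` has not yet been measured. It differs from compound 3 in a single place: hydrogen in place of methyl on a saturated chain carbon, two bonds along the chain from a carbonyl carbon. Hydrogen stands in place of methyl on a saturated chain carbon, two bonds along the chain from a carbonyl carbon, so the sec-butyl of compound 3 becomes isopropyl in compound 4. Comparing two compounds that differ in only one place is the cleanest way to read the effect of a change, but no measured pair here offers that. Compound 3 differs from compound 1 and compound 2 in many places, so those large gaps cannot serve as a guide, and the expectation rests on the structural change alone.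

With one carbon fewer in this side chain, a small downward step is expected, estimated as a number 0.40 log units lower from compound 3 to compound 4 (beyond the scatter). In this assay, the expected value for compound 4 is 4.1, with an estimated range from 3.7 to 4.5.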

Compound 4, partition coefficient: 4
Compound 4: the middle estimate sits 0.10 log units above what was measured; low and high end bracket the measured number.
By their numbers in this assay, from the lowest: compound 4; then compound 3; then compound 1; then compound 2.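

In this assay, trimming the sec-butyl to isopropyl gives a number 0.50 log units lower from compound 3 to compound 4 (beyond the scatter). For the compounds shown here, this is the first comparison here between two compounds that differ in only one place, so it is the first direct reading of what this side chain contributes, free of the many other differences that separate compound 3 from compound 1 and compound 2. It shows that replacing methyl with hydrogen on a saturated chain carbon, two bonds along the chain from a carbonyl carbon, is enough on its own to move the number beyond the usual scatter, although nothing shown gives a measured reason for the size of this step.

From the compounds shown here alone, a single pair gives one step in one direction, so it remains open whether a shorter ethyl or a longer chain such as n-pentyl at this place would continue the same trend, and what an amine or a carboxylic acid there would do to the number. Going by these compounds, it is also open whether the same change would give a step of similar size on a different core, such as that of compound 1.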